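This account rests on a few compounds, and the source may have more. Where it says the series, first, only, none or still open, it means among the compounds named here.

Measured in a functional assay on CCRF-CEM cells (Homo sapiens) for antiproliferative activity, with a stated time of 72 h; on this read-out higher numbers stand for weaker inhibition and lower numbers for stronger inhibition:
- compound 1 `OC[C@H]1O[C@@H](n2cnc3c(NCc4c(F)ccc(F)c4F)ncnc32)[C@H](O)[C@@H]1O`: 90300 nM
- compound 2 `OC[C@H]1O[C@@H](n2cnc3c(NCc4ccc(F)cc4Cl)ncnc32)[C@H](O)[C@@H]1O`: 20900 nM
- compound 3 `OC[C@H]1O[C@@H](n2cnc3c(NCc4ccc(F)c(Cl)c4)ncnc32)[C@H](O)[C@@H]1O`: 3400 nM

Of these three, compound 3 has the lowest number, 3400 nM, and so shows the strongest inhibition. Compound 4 `Cc1cccc(CNc2ncnc3c2ncn3[C@@H]2O[C@H](CO)[C@@H](O)[C@H]2O)c1O` keeps the shared core and changes one group: 2-hydroxy-3-methylphenyl in place of 3-chloro-4-fluorophenyl on a saturated chain carbon bound to a nitrogen on an aromatic ring. In words, 2-hydroxy-3-methylphenyl takes the place of 3-chloro-4-fluorophenyl.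

Going by the values given here, no measured step makes this swap. The closest evidence comes from three steps: a 4.3-fold lower number from compound 1 to compound 2 (0.64 log units; beyond the scatter), a 6.1-fold lower number from compound 2 to compound 3 (0.79 log units; beyond the scatter) and a 27-fold lower number from compound 1 to compound 3 (1.42 log units; beyond the scatter). They show that changing this group alone can shift the number by a modest to a large amount. However, all three only exchange one halogen-bearing phenyl group for another, so none shows what a hydroxy or methyl group does here. They therefore give no direction, and the expectation stays close to compound 3 at 3400 nM, with wide uncertainty.

The expected change is a 1.1-fold lower number from compound 3 to compound 4 (0.05 log units; within the scatter). For compound 4, the estimate is 3000 nM, with an expected range of 400 nM to 25000 nM.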

Compound 4, half-maximal inhibitory concentration: 900 nM
Estimate against measurement, compound 4: 3.3-fold (0.52 log units) above; the measured number falls inside the stated range.
By their numbers in this assay, from the lowest: compound 4; then compound 3; then compound 2; then compound 1.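

In this assay, putting 2-hydroxy-3-methylphenyl in place of 3-chloro-4-fluorophenyl gives a 3.8-fold lower number from compound 3 to compound 4 (0.58 log units; beyond the scatter), so among these compounds a halogen on the phenyl group is not needed for the strongest inhibition, and a group with no halogen at all can do better. The same group also gives a 23-fold lower number from compound 2 to compound 4 (1.37 log units; beyond the scatter) and a 100-fold lower number from compound 1 to compound 4 (2.00 log units; beyond the scatter), which widens the range seen from changing this one group and shows that its effect extends beyond exchanges among halogen-bearing phenyl groups. Nothing available here explains the gain in terms of any measured property of these groups.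

The hydroxy and methyl groups enter together, so the compounds shown cannot separate what each contributes. On these data alone, it also remains open whether a methoxy group or an amine on this phenyl ring would give a lower or a higher number.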